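Aryl swap at the quinolinone core and phosphatase inhibition

The compounds below may be only part of what the source reports. "The series", "measured", "known", "first", "only" and "open" are said of these compounds alone.

Compound 2 `COc1ccc(Cn2c(-c3ccc(C)cc3)c(-c3cc(C)cc(C)c3)c(=O)c3cc([N+](=O)[O-])ccc32)cc1`: 4740 nM
Compound 1 `COc1ccc(Cn2c(-c3ccc(C)cc3)c(Br)c(=O)c3cc([N+](=O)[O-])ccc32)cc1`: 4220 nM

In an assay on isolated protein for inhibition of alkaline phosphatase, tissue-nonspecific isozyme (Bos taurus), read by spectrophotometry, with stated times of 7 min and 15 min (a higher number here means a weaker inhibitor, a lower number a stronger inhibitor), compound 2 gives 4740 nM, the higher of the two numbers, with compound 1 `COc1ccc(Cn2c(-c3ccc(C)cc3)c(Br)c(=O)c3cc([N+](=O)[O-])ccc32)cc1` close at 4220 nM. For the measured compounds named here, the only measured step, a 1.1-fold higher number from compound 1 to compound 2 (0.05 log units; within the scatter), stays within the scatter. Compound 3 `COc1ccc(Cn2c(-c3ccc(C)cc3)c(-c3ccc(C(F)(F)F)cc3)c(=O)c3cc([N+](=O)[O-])ccc32)cc1` arises from compound 2 by 4-(trifluoromethyl)phenyl in place of 3,5-dimethylphenyl on an aromatic carbon. Going by the values given here, no measured step concerns one aryl group replaced by another, so nothing points in either direction. Compound 3 is therefore expected to show no change beyond the scatter in this assay, with a 1.1-fold lower number from compound 2 to compound 3 (0.02 log units; within the scatter), giving an estimated 4500 nM within 1500 nM to 13000 nM.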

Compound 3, half-maximal inhibitory concentration: 6190 nM
Compound 3: middle estimate off by 1.4-fold (0.14 log units), on the low side; measured number inside the range.
By their numbers in this assay, from the lowest: compounds 1, 2 and 3 (each within the scatter of the next).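

At this position, on the aromatic carbon ortho to a 4-methylphenyl group, exchanging one aryl group for another brings no change beyond the scatter in this assay: (a 1.3-fold higher number from compound 2 to compound 3 (0.12 log units; within the scatter)). Putting 4-(trifluoromethyl)phenyl in place of bromo is also within the scatter (a 1.5-fold higher number from compound 1 to compound 3 (0.17 log units; within the scatter)), so bromo and both aryl groups read alike here. No measurement shown bears on why this carbon tolerates these exchanges. As far as these compounds go, whether an amine or a carboxylic acid on this carbon would move the number remains open, as does the part played by the nitro group on the shared core.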